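This account rests on a few compounds, and the source may have more. Where it says the series, first, only, none or still open, it means among the compounds named here.

Compound 1 `Cc1nc(N2CCN(C3CCCC3)CC2)nc2ccc(NC(=O)COc3ccc(Cl)cc3)cc12` is the weakest inhibitor among the three compounds measured here. In a functional assay on CHO-K1 cells for antagonist activity at melanin-concentrating hormone receptor 1 (Homo sapiens), read by inositol phosphate accumulation (a higher number here means a weaker inhibitor, a lower number a stronger inhibitor), compound 1 gives 150 nM. Compound 2 `Cc1nc(N2CCC(NC(=O)C(C)C)CC2)nc2ccc(NC(=O)COc3ccc(Cl)cc3)cc12` gives 54 nM in this assay, and compound 3 `CCC1(O)CCN(c2nc(C)c3cc(NC(=O)COc4ccc(OC(F)(F)F)cc4)ccc3n2)CC1` gives 59 nM, so both sit beyond the scatter on the stronger side of compound 1.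

Compound 4 `Cc1nc(N2CCC(C)(O)CC2)nc2ccc(NC(=O)COc3ccc(Cl)cc3)cc12` has not yet been measured. It keeps the core and the chlorophenoxyacetamide of compound 1 and differs in one place: 4-hydroxy-4-methylpiperidin-1-yl in place of 4-cyclopentylpiperazin-1-yl on an aromatic carbon. This exchange removes the cyclopentyl-bearing piperazine and introduces a hydroxyl group on the piperidine ring.

Within the data shown here, no measured pair shows exactly this step, but compound 3 carries a hydroxyl-bearing piperidinyl group of the same kind on the shared core, differing further only in the aryl ether, and its value gives the nearest guide. A moderate improvement is therefore expected, beyond the scatter, as the step of a 2.5-fold lower number from compound 1 to compound 4 (0.40 log units; beyond the scatter). Compound 4 is estimated at 60 nM, with a range from 25 nM to 150 nM, because compound 3 gives 59 nM in this assay.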

Compound 4, half-maximal inhibitory concentration: 827 nM
For compound 4 the middle estimate is 14-fold (1.14 log units) below the measured one; the measured number lies above the stated range.
By their numbers in this assay, from the lowest: compounds 2 and 3 (each within the scatter of the next); then compound 1; then compound 4.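

In this assay, placing 4-hydroxy-4-methylpiperidin-1-yl on the shared core in place of 4-cyclopentylpiperazin-1-yl gives a 5.5-fold higher number from compound 1 to compound 4 (0.74 log units; beyond the scatter), so compound 4 is the weaker inhibitor. Among these compounds, this is the first pair here that differs in this one place alone, and it shows that the group on this aromatic carbon, between two ring nitrogen atoms, can shift the inhibition beyond the scatter. The exchange alters several features at once, including the cyclopentyl ring, the second ring nitrogen and the hydroxyl group, and nothing available here explains the loss.

The compounds shown leave open which of these features accounts for the step. A piperazine bearing a methyl group, or a piperidine bearing only a 4-methyl group, would help to separate them.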